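The source may report more compounds than this note shows. Statements on the series, on what has been measured and on what is new or still open speak of the compounds shown alone.

Of the compounds shown here, three have been read so far in a functional assay on MCF7 cells (Homo sapiens) for antiproliferative activity, read by colorimetric assay and sulforhodamine B assay, with a stated time of 3 days; a higher number here means a weaker inhibitor, a lower number a stronger inhibitor. Compound 1 `Brc1ncnc2c1ncn2CC1COc2ccccc2S1` gives 6180 nM in this series. Compound 2 `Nc1ncnc2c1ncn2CC1CSc2ccccc2O1` reads > 30000 nM, which is a limit of the assay and not a number. Compound 3 `Clc1ncnc2c1ncn2CC1COc2ccccc2O1` gives 18800 nM, the higher of the two actual numbers. The gap down to the 6180 nM of compound 1 lies beyond the scatter, but compound 1 also differs from compound 3 elsewhere in the structure.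

The next step leads to compound 4 `Brc1ncnc2c1ncn2CC1COc2ccccc2O1`, with bromo in place of chloro on an aromatic carbon. Among the measured compounds shown here, no measured pair isolates this exchange, so the size of the step cannot be read directly from the data. For the measured compounds named here, the only guide is compound 1, which carries bromo and gives 6180 nM, and this points weakly towards a lower number in this assay. Since that comparison also includes the other structural difference, only part of the gap is carried over. The expected 1.7-fold lower number from compound 3 to compound 4 (0.23 log units; within the scatter) is small, towards a lower number and not clearly beyond the scatter. For compound 4 the estimated value is 11000 nM, with an expected range of 5000 nM to 25000 nM.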

Compound 4, half-maximal inhibitory concentration: 7640 nM
Compound 4: the middle estimate sits 1.4-fold (0.16 log units) above what was measured, within the range that was stated.
By their numbers in this assay, from the lowest: compounds 1 and 4 (each within the scatter of the next); then compound 3. At a limit, above all of these: compound 2.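

The series now holds its first pair that differs in one place only: in this assay, bromo in place of chloro on an aromatic carbon gives a 2.5-fold lower number from compound 3 to compound 4 (0.39 log units; beyond the scatter). This exchange swaps one heavy atom for one heavy atom, with no hydrogen-bond donor or acceptor on either side, so a modest step beyond the scatter can arise at this position from the halogen alone. The two bromo compounds also differ from each other in one place, and compound 1 at 6180 nM and compound 4 at 7640 nM lie within the scatter of each other, so that difference in the rest of the structure shows no clear effect on the number here.

No measurement shown bears on this exchange, so no reason for the step can be given. Going by these compounds, it remains open whether fluoro, iodo or a methyl group on this aromatic carbon would extend the trend from chloro to bromo or break it, and whether chloro and bromo would differ by a similar step on the core of compound 1.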